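Swapping the sulfonyl hydroxy for a bromopyridinylamino group

This account rests on a few compounds, and the source may have more. Where it says the series, first, only, none or still open, it means among the compounds named here.

For the measured compounds named here, compound 1, `O=S(=O)(O)CSc1nnc(Br)n1Cc1ccc(Br)c2ccccc12`, is the weakest of the three measured members in an assay on HEK293 cells for inhibition of solute carrier family 22 member 12 (Homo sapiens) (a lower number here means a stronger inhibitor, a higher number a weaker inhibitor), where compound 1 gives 14400 nM. Two analogues carry an aminopyridine in place of the hydroxy group on the sulfonyl sulfur of the shared core. Compound 2, `O=S(=O)(CSc1nnc(Br)n1Cc1ccc(Br)c2ccccc12)Nc1ccc(F)nc1`, gives 1550 nM in this assay, and compound 3, `O=S(=O)(CSc1nnc(Br)n1Cc1ccc(Br)c2ccccc12)Nc1cc(Cl)cnc1Cl`, gives 2790 nM. The step of a 9.3-fold lower number from compound 1 to compound 2 (0.97 log units; beyond the scatter) and the step of a 5.2-fold lower number from compound 1 to compound 3 (0.71 log units; beyond the scatter) are both beyond the scatter, while the step of a 1.8-fold higher number from compound 2 to compound 3 (0.26 log units; within the scatter) lies within it, so the two aminopyridines behave alike.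

Compound 4, `O=S(=O)(CSc1nnc(Br)n1Cc1ccc(Br)c2ccccc12)Nc1cccnc1Br`, differs from compound 1 by the change ((2-bromopyridin-3-yl)amino in place of hydroxy on a sulfonyl sulfur). This is the same kind of replacement that separates compound 1 from compound 2 and from compound 3, so the steps of a 9.3-fold lower number from compound 1 to compound 2 (0.97 log units; beyond the scatter) and a 5.2-fold lower number from compound 1 to compound 3 (0.71 log units; beyond the scatter) bear directly on it. A step of that order, towards a lower number, is therefore expected for compound 4, namely a 6.5-fold lower number from compound 1 to compound 4 (0.82 log units; beyond the scatter). Compound 4 is accordingly estimated at 2200 nM in this assay, with a range from 900 nM to 5500 nM.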

Compound 4, half-maximal inhibitory concentration: 280 nM
The estimate for compound 4 lay 7.9-fold (0.90 log units) above the measured number, and the stated range ends above it.
By their numbers in this assay, from the lowest: compound 4; then compounds 2 and 3 (each within the scatter of the next); then compound 1.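

With a 51-fold lower number from compound 1 to compound 4 (1.71 log units; beyond the scatter) in this assay, (2-bromopyridin-3-yl)amino on the sulfonyl sulfur goes well beyond what the earlier replacements of hydroxy had shown, and compound 4 is the strongest inhibitor of the four. Compounds 2 and 3 had not been told apart, so the group on the sulfonamide nitrogen could have seemed to matter little, yet a 10-fold lower number from compound 3 to compound 4 (1.00 log units; beyond the scatter) and a 5.5-fold lower number from compound 2 to compound 4 (0.74 log units; beyond the scatter) are both beyond the scatter, which shows that the number depends on which pyridine is carried there and not merely on hydroxy having been replaced. Nothing available bears on what sets the 2-bromopyridin-3-yl group apart from the other two pyridines.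

The compounds shown leave open whether a chlorine, a methyl or a methoxy in place of the bromine of the 2-bromopyridin-3-yl group would keep this low number. They also leave open whether the pyridine nitrogen counts at all, as a plain 2-bromophenyl group on the sulfonamide nitrogen would show.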